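A few compounds are considered here, and "the series" means these few. Any claim that something is new, unique, unknown or untested is made for them only; others in the source may bear on it.

Measured so far in a toxicity assay on MT4 cells (Homo sapiens) for cytotoxicity, read by MTT assay; on this read-out lower numbers stand for higher toxicity in this test and higher numbers for lower toxicity in this test:
compound 1 (`Cc1cc(-c2ccc(F)cc2)cc(C)c1Oc1cc(N)nc(Nc2ccc(C#N)cc2)n1`) gives 23100 nM
compound 2 (`Cc1cc(-c2ccccc2F)ccc1Oc1cc(N)nc(Nc2ccc(C#N)cc2)n1`) gives 29500 nM

Compound 2, at 29500 nM in this assay, stands within the usual scatter of compound 1, so the two values cannot be told apart. Compound 3 (`Cc1cc(-c2ccc(F)cc2)ccc1Oc1cc(N)nc(Nc2ccc(C#N)cc2)n1`) has not yet been measured. It differs from compound 2 by a single change (4-fluorophenyl in place of 2-fluorophenyl on an aromatic carbon): 4-fluorophenyl in place of 2-fluorophenyl on an aromatic carbon, meta to a methyl group and para to a large group. Among the measured compounds shown here, no measured pair shows this change alone. Compound 1, which also carries 4-fluorophenyl, gives 23100 nM in a range shared with compound 2, and so no shift beyond the scatter is expected in this assay. The estimated step (a 1.2-fold lower number from compound 2 to compound 3 (0.07 log units; within the scatter)) is expected to stay within the scatter. Compound 3 is estimated at 25000 nM (expected range 11000 nM to 60000 nM).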

Compound 3, half-maximal cytotoxic concentration: 20100 nM
Estimate against measurement, compound 3: 1.2-fold (0.09 log units) above; low and high end bracket the measured number.
By their numbers in this assay, from the lowest: compounds 3, 1 and 2 (each within the scatter of the next).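

In this assay, the exchange of 2-fluorophenyl for 4-fluorophenyl on an aromatic carbon can now be read directly as a 1.5-fold lower number from compound 2 to compound 3 (0.17 log units; within the scatter) and so does not move the number beyond the scatter. Among the compounds shown here, compound 3 also gives the first reading of hydrogen in place of methyl on an aromatic carbon, as a 1.1-fold lower number from compound 1 to compound 3 (0.06 log units; within the scatter) with 4-fluorophenyl present in both compounds, and this change likewise stays within the scatter. No supporting data bear on why these values remain so close.

The compounds shown leave open what a group such as an amine, a methoxy group or a carboxylic acid would do in place of the fluorine on the phenyl group. They also leave open whether an ethyl group in place of the methyl group would give a step beyond the scatter.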